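The source may report more compounds than this note shows. Statements on the series, on what has been measured and on what is new or still open speak of the compounds shown alone.

Of the compounds shown here, two of one shared core have been tested in a functional assay on U-251 cells (Homo sapiens) for inhibition, read by sulforhodamine B assay, with a stated time of 48 h; a higher number here means a weaker inhibitor of growth, a lower number a stronger inhibitor of growth. Compound 1 `COc1ccc(-c2cc(/C=C/C(=O)c3ccc(N)cc3)[nH]n2)cc1` carries a single methoxy group on its outer benzene ring, and in this assay compound 1 gives 2570 nM. Compound 2 `COc1cc(-c2cc(/C=C/C(=O)c3ccc(N)cc3)[nH]n2)cc(OC)c1OC` carries three methoxy groups on that ring, and in this assay compound 2 gives 2770 nM. The two numbers lie within the usual scatter of one another, so on the evidence so far compound 2 and compound 1 cannot be told apart in this assay.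

Compound 3 `COc1ccc(-c2cc(/C=C/C(=O)c3ccc(N)cc3)[nH]n2)cc1OC` sits between them in substitution. It differs from compound 2 in one place: hydrogen in place of methoxy on an aromatic carbon, so that two methoxy groups remain. Among the measured compounds shown here, no measured pair shows what removing one methoxy group does here, but compound 1 and compound 2 bracket this change and give numbers within the scatter of each other, so no step beyond the scatter is expected from compound 2 to compound 3 in this assay. The estimated step is a 1.0-fold lower number from compound 2 to compound 3 (0.01 log units; within the scatter). Compound 3 is therefore expected to give about 2700 nM in this assay, within a range from 1300 nM to 5500 nM.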

Compound 3, concentration for total growth inhibition: 3660 nM
Compound 3: middle estimate off by 1.4-fold (0.13 log units), on the low side, within the range that was stated.
By their numbers in this assay, from the lowest: compounds 1, 2 and 3 (each within the scatter of the next).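

In this assay, among the compounds shown here, hydrogen in place of methoxy gives a 1.3-fold higher number from compound 2 to compound 3 (0.12 log units; within the scatter) at a carbon that is ortho to a methoxy group and meta to a large group, and this is the first measured pair to isolate that change. The second single change leading to the same compound, methoxy in place of hydrogen on an aromatic carbon, gives a 1.4-fold higher number from compound 1 to compound 3 (0.15 log units; within the scatter) and so adds a measured pair of its own. With both steps inside the scatter, a methoxy group and a hydrogen cannot be told apart at either of these two carbons in these compounds, and nothing measured here speaks to why the numbers stay so close.

For the compounds shown here, whether a hydroxy group, a fluorine atom or a dimethylamino group on this ring would give a step beyond the scatter remains open, since methoxy and hydrogen are the only groups compared here. Also open, going by these compounds, is whether changing the amino group of the shared core, for instance to an acetamide, would move the number any further than these methoxy changes do.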